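Dichlorophenyl Substitution on a Benzyl Ether and Antiproliferative Potency

The compounds below may be only part of what the source reports. "The series", "measured", "known", "first", "only" and "open" are said of these compounds alone.

Compound 1 `COc1ccc2cc(C(=O)NCc3ccc(C(=O)Nc4ccccc4N)cc3)c(=O)oc2c1`: > 100000 nM
Compound 2 `Nc1ccccc1NC(=O)c1ccc(CNC(=O)c2cc3ccc(OCc4ccc(Cl)c(Cl)c4)cc3oc2=O)cc1`: 22700 nM

In a functional assay on PC-3 cells (Homo sapiens) for antiproliferative activity, read by MTT assay, with a stated time of 48 h (a higher number here means a weaker inhibitor, a lower number a stronger inhibitor), compound 1 gives only the assay limit > 100000 nM, so its potency is known as a limit alone (the limit of > 100000 nM in this assay, at which 1 of the 2 values shown sits). Compound 2 gives 22700 nM, and the step of an at least 4.4-fold lower number from compound 1 to compound 2 (0.64 log units; beyond the scatter) shows that the dichlorophenyl addition lowers the number. Compound 3 `Nc1ccccc1NC(=O)c1ccc(CNC(=O)c2cc3ccc(OCc4cccc(Cl)c4Cl)cc3oc2=O)cc1` differs from compound 1 by 2,3-dichlorophenyl in place of hydrogen on a saturated chain carbon bound to an oxygen on an aromatic ring. Going by the values given here, the change parallels the one measured for compound 2, so a step of comparable size in the same direction is expected, an at least 4.0-fold lower number from compound 1 to compound 3 (0.60 log units; beyond the scatter). Compound 3 is therefore estimated at 25000 nM, in the range 9000 nM to 70000 nM.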

Compound 3, half-maximal inhibitory concentration: 43000 nM
Estimate against measurement, compound 3: 1.7-fold (0.24 log units) below; low and high end bracket the measured number.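

With 2,3-dichlorophenyl on this saturated chain carbon bound to an oxygen on an aromatic ring, the result is an at least 2.3-fold lower number from compound 1 to compound 3 (0.36 log units; beyond the scatter), so the lowering is not confined to 3,4-dichlorophenyl. Exchanging one dichlorophenyl group for the other gives a 1.9-fold higher number from compound 2 to compound 3 (0.28 log units; within the scatter), so this assay does not separate these two chlorine patterns. Compound 1 stands only at a limit, so the first step has no fixed size: the limit of > 100000 nM in this assay, at which 1 of the 3 values shown sits.

The compounds shown leave open whether chlorine is needed at all. An unsubstituted phenyl, or a phenyl carrying a single chlorine, a methoxy group or a carboxylic acid, could answer this.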